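The source may report more compounds than this note shows. Statements on the series, on what has been measured and on what is new or still open speak of the compounds shown alone.

Among the measured compounds shown here, in a physicochemical assay for lipophilicity (a higher number here means a more lipophilic compound, a lower number a more polar compound), compound 1 (`CC(C)c1ncc([C@@H](CCCCCCc2ccc3c(n2)NCCC3)CC(=O)O)cn1`) gives 1.32 and compound 2 (`O=C(O)C[C@H](CCCCCCc1ccc2c(n1)NCCC2)c1cnc2ccccc2c1`) gives 2.39, which leaves compound 1 with the lower of the only two numbers available. Compound 3 (`COc1ccc([C@@H](CCCCCCc2ccc3c(n2)NCCC3)CC(=O)O)cn1`) has not yet been measured. Its structure carries 6-methoxypyridin-3-yl in place of 2-isopropylpyrimidin-5-yl on a saturated chain carbon bound to two saturated chain carbons.

For the measured compounds named here, only one measured step bears on this change. At the same place, quinolin-3-yl in place of 2-isopropylpyrimidin-5-yl gave a number 1.07 log units higher from compound 1 to compound 2 (beyond the scatter), a large step beyond the scatter. That step shows that the number in this assay can move substantially with the group at this place. However, it involves a different entering group, so its size cannot simply be carried over. A much smaller move in the same direction is expected here, and it may not clear the scatter. The expected step is a number 0.28 log units higher from compound 1 to compound 3 (within the scatter). For compound 3, the estimated value is 1.6, with an expected range of 1.2 to 2.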

Compound 3, partition coefficient: 1.67
For compound 3 the middle estimate is 0.07 log units below the measured one; the measured number falls inside the stated range.
By their numbers in this assay, from the lowest: compound 1; then compound 3; then compound 2.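

The first step shows that a change of group at this place can clear the scatter even when the two groups are closely matched: in this assay, 6-methoxypyridin-3-yl in place of 2-isopropylpyrimidin-5-yl gives a number 0.35 log units higher from compound 1 to compound 3 (beyond the scatter), although the entering group has fewer heavy atoms, a single ring like the leaving group and the same count of hydrogen-bond acceptors. The position now shows a graded range rather than a single large jump, since 6-methoxypyridin-3-yl in place of quinolin-3-yl gives a number 0.72 log units lower from compound 2 to compound 3 (beyond the scatter), which puts all three groups apart from one another beyond the scatter. Nothing available explains why the numbers fall in this order.

The compounds shown do not separate the contribution of the methoxy group from that of the ring carrying it, and a plain phenyl ring or a 6-ethoxypyridin-3-yl group at this place would bear directly on that question. They also leave open whether these steps keep their size when the carboxylic acid or the six-carbon stretch of the chain is replaced, for instance by a primary amide or a longer chain.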